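The compounds below may be only part of what the source reports. "The series", "measured", "known", "first", "only" and "open" are said of these compounds alone.

Working notes on the series. The set is built around a shared core carrying a 4-hydroxyphenyl group, and it has been tested in an assay on isolated protein for inhibition of DNA topoisomerase 1 (Homo sapiens), with a stated time of 30 min, tested at 100 uM; on this read-out higher numbers stand for a stronger effect at the one concentration tested and lower numbers for a weaker effect. Compound 1, `Oc1ccc(-c2cc(-c3ccccc3)nc(-c3ccc(Cl)cc3)c2)cc1`, is the reference point; in this assay compound 1 gives 68%. Compound 2, `Oc1ccc(-c2cc(-c3ccsc3)nc(-c3cccc(Cl)c3)c2)cc1`, gives 26% in this assay and so stands at the lowest of the two numbers seen so far, with compound 1 the nearer neighbour and the gap between the two beyond the usual scatter. Among the compounds with values here, compound 2 and compound 1 differ in two places, so no single step between measured compounds is available.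

Compound 3, `Oc1ccc(-c2cc(-c3ccccc3)nc(-c3cccc(Cl)c3)c2)cc1`, is not yet measured. It differs from compound 2 in one place: phenyl in place of thiophen-3-yl on an aromatic carbon. The move places compound 3 nearer to compound 1 in structure, since only the position of the chlorine on the 3-chlorophenyl group versus the 4-chlorophenyl group now separates them. On this basis the step in this assay is expected to be upward, of the size a number 26 percentage points higher from compound 2 to compound 3 (beyond the scatter), and beyond the scatter. The estimate for compound 3 in this assay is therefore 52%, expected to fall between 32% and 70%.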

Compound 3, a percentage reported as inhibition, at one concentration (the size of the read-out at that concentration, not a potency): 0%
Beside the measured number, compound 3's estimate is 52 percentage points above it; measured number outside the range, below it.
By their numbers in this assay, from the lowest: compound 3; then compound 2; then compound 1.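

In this assay, phenyl in place of thiophen-3-yl on the aromatic carbon next to the ring nitrogen, with the 3-chlorophenyl group unchanged, gives a number 26 percentage points lower from compound 2 to compound 3 (beyond the scatter), so this position does respond to the choice of aromatic ring, and here thiophen-3-yl gives the higher number. With phenyl held constant, 3-chlorophenyl in place of 4-chlorophenyl gives a number 68 percentage points lower from compound 1 to compound 3 (beyond the scatter), a large step showing that the placement of the chlorine alone is enough to take the read-out in this assay down to the 0% of compound 3. Nothing at hand accounts for either step.

The compounds shown leave open whether thiophen-3-yl would still give the higher number than phenyl alongside a 4-chlorophenyl group, and so whether the two changes act independently or depend on each other. Also open, going by these compounds, is how the position next to the ring nitrogen would respond to a non-aromatic group such as an amine, and how a methoxy group or a nitrile would compare with the chlorine.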